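Fluorines on the benzoyl ring of a dopamine transporter ligand

This account rests on a few compounds, and the source may have more. Where it says the series, first, only, none or still open, it means among the compounds named here.

Measured so far:
- compound 1, `O=C(c1ccccc1)N1CCC(NCCSC(c2ccc(F)cc2)c2ccc(F)cc2)CC1`, 4.51 nM
- compound 2, `CC(C)(C)C(=O)N1CCC(NCC[S+]([O-])C(c2ccc(F)cc2)c2ccc(F)cc2)CC1`, 10200 nM
- compound 3, `CC(C)(C)CN1CCC(NCC[S+]([O-])C(c2ccc(F)cc2)c2ccc(F)cc2)CC1`, 431 nM

In an assay on membranes from striatum (strain Sprague-Dawley) for displacement of a labelled ligand from sodium-dependent dopamine transporter (Rattus norvegicus), read by scintillation counting, with a stated time of 120 min (on this read-out lower numbers stand for stronger inhibition and higher numbers for weaker inhibition), compound 1 gives the lowest number of the three. Compound 4, `O=C(c1ccc(F)cc1F)N1CCC(NCCSC(c2ccc(F)cc2)c2ccc(F)cc2)CC1`, differs from compound 1 by 2,4-difluorophenyl in place of phenyl on a carbonyl carbon, that is, benzoyl to (2,4-difluorophenyl)carbonyl. Going by the values given here, the only measured step, a 24-fold lower number from compound 2 to compound 3 (1.37 log units; beyond the scatter), concerns the group on the ring nitrogen in the sulfoxide pair and does not touch the benzoyl ring, so no measured step speaks directly to this change. Because compound 1 already gives 4.51 nM, the expectation is a step of a 1.1-fold higher number from compound 1 to compound 4 (0.04 log units; within the scatter), within the scatter. Compound 4 is therefore estimated at 5 nM, with a range from 2 nM to 15 nM.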

Compound 4, inhibition constant: 30 nM
The estimate for compound 4 lay 6.0-fold (0.78 log units) below the measured number; the measured number lies above the stated range.
By their numbers in this assay, from the lowest: compound 1; then compound 4; then compound 3; then compound 2.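

In this assay, replacing phenyl on the carbonyl carbon with 2,4-difluorophenyl gives a 6.7-fold higher number from compound 1 to compound 4 (0.82 log units; beyond the scatter), a modest loss of strength beyond the scatter. This shows that the aromatic ring on the carbonyl is not indifferent to substitution, which the earlier step, made at the ring nitrogen, could not show. No supporting measurement here explains the loss. On these data alone, whether a single fluorine would produce the same step remains open. So does how a chlorine, a methoxy group or a nitrile on this ring would compare.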